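The compounds below may be only part of what the source reports. "The series", "measured", "known", "first", "only" and "open" are said of these compounds alone.

Compound 1 `COC(=O)/C=C/c1cccc(N(Cc2ccc(/C=C/c3cc(C(F)(F)F)cc(C(F)(F)F)c3)cc2)C(=O)C2CCCCC2)c1`: 1470 nM in an assay on isolated protein with Bile acid receptor (Homo sapiens) as the target; a lower number here means that less compound is needed, a higher number that more compound is needed for the effect
Compound 2 `COC(=O)/C=C/c1cccc(N(Cc2ccc(-c3ccc(F)c(F)c3)cc2)C(=O)C2CCCCC2)c1`: 72 nM
Compound 3 `COC(=O)/C=C/c1cccc(N(Cc2ccc(-c3ccc(F)c(Cl)c3)cc2)C(=O)C2CCCCC2)c1`: 66 nM

Compound 3 stands at the lowest of the three numbers. Its nearest neighbour is compound 2, and the step of a 1.1-fold lower number from compound 2 to compound 3 (0.04 log units; within the scatter) lies within the scatter. Compound 1 gives 1470 nM, a much higher number than compound 3, beyond the scatter. Compound 4 `COC(=O)/C=C/c1cccc(N(Cc2ccc(/C=C/C(=O)N(C)C)cc2)C(=O)C2CCCCC2)c1` differs from compound 3 by 2-(dimethylcarbamoyl)ethenyl in place of 3-chloro-4-fluorophenyl on an aromatic carbon. Within the data shown here, the only measured step, a halogen swap, does not bear on removing the ring, so no close precedent exists. The large gap between compound 1 and compound 3 suggests that changes at this place can cost much. Compound 4 is therefore expected to give a higher number, around 600 nM (range 150 nM to 3000 nM). The expected step is a 9.1-fold higher number from compound 3 to compound 4 (0.96 log units; beyond the scatter).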

Compound 4, half-maximal effective concentration: > 1000 nM
Compound 4 gave a limit, no number; the forecaster's own chance of this, stated with the estimate: 5%; middle value at least 1.6-fold (0.22 log units) from the limit.
By their numbers in this assay, from the lowest: compounds 3 and 2 (each within the scatter of the next); then compound 1.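

The result for compound 4 is a limit and not a number: the limit of > 1000 nM in this assay, at which 1 of the 4 values shown sits. In this assay, 2-(dimethylcarbamoyl)ethenyl in place of 3-chloro-4-fluorophenyl gives an at least 15-fold higher number from compound 3 to compound 4 (1.18 log units; beyond the scatter), and in place of 3,4-difluorophenyl it gives an at least 13-fold higher number from compound 2 to compound 4 (1.14 log units; beyond the scatter). The halogen swap stayed within the scatter, whereas exchanging the whole aromatic ring on this carbon for this open chain is a large step.

On these data alone, how far compound 4 lies past its limit stays open. Also open, as far as these compounds go, is how a carboxylic acid or an amine at this place would compare.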